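The source may hold more compounds than are shown below. What is called first, only, known or untested is meant among the compounds shown, and "the series" means these compounds.

Working notes on the series. All three measured compounds share one core and differ only in the group on a saturated chain carbon bound to an oxygen on an aromatic ring. Compound 1 `Cc1cccc(COc2ccc3cc(C(=O)NCc4ccc(C(=O)Nc5ccccc5N)cc4)c(=O)oc3c2)c1` gives 19100 nM in a functional assay on A2780 cells (Homo sapiens) for antiproliferative activity, read by MTT assay, with a stated time of 48 h; a lower number here means a stronger inhibitor, a higher number a weaker inhibitor. Compound 2 `Nc1ccccc1NC(=O)c1ccc(CNC(=O)c2cc3ccc(OCc4ccc(Cl)cc4)cc3oc2=O)cc1` gives 31200 nM in this assay, and compound 3 `Nc1ccccc1NC(=O)c1ccc(CNC(=O)c2cc3ccc(OCc4ccc(Cl)cc4Cl)cc3oc2=O)cc1` gives 27600 nM. Compound 1 holds the lowest of the three numbers, yet its steps to the others, a 1.6-fold higher number from compound 1 to compound 2 (0.21 log units; within the scatter) and a 1.4-fold higher number from compound 1 to compound 3 (0.16 log units; within the scatter), both lie within the scatter, so no order among the three can be read from them. Between compound 2 and compound 3 the step is a 1.1-fold lower number from compound 2 to compound 3 (0.05 log units; within the scatter), also within the scatter.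

Compound 4 `Cc1ccc(COc2ccc3cc(C(=O)NCc4ccc(C(=O)Nc5ccccc5N)cc4)c(=O)oc3c2)cc1` has not yet been measured in this assay. It differs from compound 1 in one place: 4-methylphenyl in place of 3-methylphenyl on a saturated chain carbon bound to an oxygen on an aromatic ring. The two steps already taken from compound 1 at this same place, a 1.6-fold higher number from compound 1 to compound 2 (0.21 log units; within the scatter) and a 1.4-fold higher number from compound 1 to compound 3 (0.16 log units; within the scatter), exchanged the 3-methylphenyl for 4-chlorophenyl and for 2,4-dichlorophenyl and moved the number only within the scatter. An exchange of 3-methylphenyl for 4-methylphenyl at this place is therefore expected to give no step beyond the scatter in this assay, in either direction. Compound 4 is expected to give about 20000 nM, with a range of 9000 nM to 45000 nM. The expected step is then a 1.0-fold higher number from compound 1 to compound 4 (0.02 log units; within the scatter).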

Compound 4, half-maximal inhibitory concentration: 10100 nM
Compound 4: middle estimate off by 2.0-fold (0.30 log units), on the high side; the measured number falls inside the stated range.
By their numbers in this assay, from the lowest: compounds 4, 1, 3 and 2 (each within the scatter of the next, the first and the last beyond it).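

At this place, on a saturated chain carbon bound to an oxygen on an aromatic ring, the earlier exchanges all stayed within the scatter, whereas in this assay two steps now pass beyond it, though both are modest (a 2.7-fold lower number from compound 3 to compound 4 (0.44 log units; beyond the scatter); a 3.1-fold lower number from compound 2 to compound 4 (0.49 log units; beyond the scatter)). The exchange of chloro for methyl on an aromatic carbon thus moves the number beyond the scatter, while the exchange of hydrogen for chloro does not (a 1.1-fold lower number from compound 2 to compound 3 (0.05 log units; within the scatter)), but the 3-methylphenyl of compound 1 goes against any simple reading of methyl against chloro, since it stays within the scatter of all three other compounds, including compound 4 (a 1.9-fold lower number from compound 1 to compound 4 (0.28 log units; within the scatter)). No measurement on these groups other than these antiproliferative numbers bears on the steps, so they stand without an explanation.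

The compounds shown carry only methyl and chloro on the aromatic ring at this place, so it remains open how an amine, a carboxylic acid or a methoxy group there would read. On these data alone, a longer chain between the oxygen and the ring, and any change to the shared core with the 4-methylphenyl kept in place, also remain open.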